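The compounds below may be only part of what the source reports. "The series", "measured", "known", "first", "only" and "open" are said of these compounds alone.

Compound 1 `CCOC(=O)c1cnc(CC)nc1NN1C(=O)C=C(C)C1=O` is the starting point. Within the data shown here, in a functional assay on Jurkat cells for inhibition of nuclear factor NF-kappa-B complex (Homo sapiens) (a lower number here means a stronger inhibitor, a higher number a weaker inhibitor), compound 1 gives 10000 nM, which is the higher of the two numbers measured so far. Among the measured compounds shown here, compound 2 `CCOC(=O)c1cnc(C(C)(C)C)nc1NN1C(=O)C=C(C)C1=O`, which differs from it only at one carbon of the ring, gives 1000 nM in this assay, and the step of a 10-fold lower number from compound 1 to compound 2 (1.00 log units; beyond the scatter) is the only measured change available for comparison.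

Compound 3 `CCOC(=O)c1cnc(SC)nc1NN1C(=O)C=C(C)C1=O` has not yet been measured. It arises from compound 1 by methylsulfanyl in place of ethyl on an aromatic carbon. For the measured compounds named here, this is a different kind of exchange from the one between compound 1 and compound 2: there a larger branched group replaced ethyl, whereas here a group of the same heavy-atom count, carrying a sulfur and one hydrogen-bond acceptor, takes the same place. Going by the values given here, no measured step covers such an exchange, so the step from compound 1 to compound 2 gives only a weak hint that altering this position can matter.

The number for compound 3 in this assay is therefore estimated as 7000 nM, within a range from 2000 nM to 30000 nM. This estimate means an expected step of a 1.4-fold lower number from compound 1 to compound 3 (0.15 log units; within the scatter), with no clear direction beyond the scatter.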

Compound 3, half-maximal inhibitory concentration: 200 nM
Compound 3: the middle estimate sits 35-fold (1.54 log units) above what was measured, outside the stated range (below it).
By their numbers in this assay, from the lowest: compound 3; then compound 2; then compound 1.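

In this assay the ring carbon between two ring nitrogen atoms proves far more responsive than the earlier pair could show: methylsulfanyl in place of ethyl gives a 50-fold lower number from compound 1 to compound 3 (1.70 log units; beyond the scatter), even though both groups have 2 heavy atoms. Methylsulfanyl also goes past the larger tert-butyl group, with a 5.0-fold lower number from compound 2 to compound 3 (0.70 log units; beyond the scatter), so a bigger group is not what gives the lowest number among these three compounds, and swapping one carbon for sulfur at an unchanged heavy-atom count produces the largest step seen so far. Nothing available explains why this exchange has so large an effect.

On these data alone, it remains open whether sulfur itself is needed, which a methoxy group or an amine at the same place could help to show, and whether a longer chain on the sulfur, such as ethylsulfanyl, would lower the number further or raise it again. It is also unknown whether methylsulfanyl would give a similar gain with a different group in place of the ethoxycarbonyl group, for example a carboxylic acid.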